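The source may hold more compounds than are shown below. What is called first, only, known or untested is meant among the compounds shown, and "the series" means these compounds.

Measured so far in an ADME assay on microsomes from liver (Mus musculus) for metabolic stability, with a stated time of 30 min; a higher number here means that more of the compound is left, a lower number that less of the compound is left:
Compound 1 `O=C(O)[C@H](CO)NC(=O)N1CCCC1`: "not determined" (no result reported)
Compound 2 `COC(=O)C(=O)N[C@@H](CO)C(=O)O`: "not determined" (no result reported)
Compound 3 `CN(C)C(=O)N[C@@H](CO)C(=O)O`: 30%

Within the data shown here, compound 3 holds the only number. Among the measured compounds shown here, with no result reported for the other two entries, it cannot be ranked against anything, and no measured step exists to show how far a single change moves this assay.

The next compound to be measured is compound 4 `COC(=O)N[C@@H](CO)C(=O)O`. It differs from compound 3 as follows: methoxy in place of dimethylamino on a carbonyl carbon. This places methoxy in place of dimethylamino on a carbonyl carbon, and the rest of the structure stays the same.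

The only anchor for an expectation is compound 3 at 30%. The series offers no evidence for a large change, so a modest upward step is expected, one that may not exceed the usual scatter. The estimated change is a number 5 percentage points higher from compound 3 to compound 4 (within the scatter). For the measured compounds named here, with no measured step for calibration, the range is kept wide. For compound 4 the expected value is 35%, within an estimated range of 15% to 60%.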

Compound 4, percent of the compound remaining: 27%
The estimate for compound 4 lay 8 percentage points above the measured number; the range from low to high includes it.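

In this assay the series now has its first measured step, a number 3 percentage points lower from compound 3 to compound 4 (within the scatter) for methoxy in place of dimethylamino on a carbonyl carbon. On this single pair, the exchange of the two groups at this place does not separate the compounds beyond the scatter, so it gives no sign that either group is preferred in this assay here. No measured evidence bears on this result.

The compounds shown leave open what a longer chain such as ethoxy, or a primary amine, would give at this carbonyl carbon in this assay as a read-out. They also leave open whether a primary amide in place of the carboxylic acid of the shared core would move the number by more than the step seen here.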